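Compound 4: benzyloxycarbonyl in place of the amide chain

The source may report more compounds than this note shows. Statements on the series, on what has been measured and on what is new or still open speak of the compounds shown alone.

Values in an ADME assay on L929 cells (Mus musculus) for cytotoxicity, read by resazurin assay, with a stated time of 48 h (a higher number here means that more compound is tolerated, a lower number that less compound is tolerated), so far
- compound 1 `O=c1c2cc([N+](=O)[O-])ccc2n(CCCBr)n1Cc1ccccc1` gives 25200 nM
- compound 2 `CNC(=O)CCCn1c2ccc([N+](=O)[O-])cc2c(=O)n1Cc1ccccc1` gives > 256000 nM (a limit)
- compound 3 `CN(C)C(=O)CCCn1c2ccc([N+](=O)[O-])cc2c(=O)n1Cc1ccccc1` gives > 256000 nM (a limit)

Compound 3 gives > 256000 nM as a limit and no number. Going by these compounds, this is the limit of > 256000 nM in this assay, at which 2 of the 3 values shown sit, and so the true value remains open.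

Compound 4 `O=C(OCc1ccccc1)n1c2ccc([N+](=O)[O-])cc2c(=O)n1Cc1ccccc1` has benzyloxycarbonyl in place of 3-(dimethylcarbamoyl)propyl on an aromatic nitrogen in the shared core.

For the measured compounds named here, two measured steps bear on this substituent: an at least 10-fold higher number from compound 1 to compound 2 (1.00 log units; beyond the scatter) and an at least 10-fold higher number from compound 1 to compound 3 (1.00 log units; beyond the scatter) are both beyond the scatter. The third, a step that the two limits leave unreadable from compound 2 to compound 3, adds nothing. Going by the values given here, no measured step replaces the whole chain, so the guide is loose. Both carbamoyl compounds sit at the limit. Compound 1 gives 25200 nM, so a lower number is expected in this assay once the carbamoyl chain is gone. The expected change is an at least 4.2-fold lower number from compound 3 to compound 4 (0.63 log units; beyond the scatter) as estimated here. For compound 4 the estimated value is 60000 nM with an expected range of 12000 nM to 256000 nM in this assay.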

Compound 4, concentration lethal to 50% of the cells: 86100 nM
Compound 4: middle estimate off by 1.4-fold (0.16 log units), on the low side; measured number inside the range.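

In this assay, benzyloxycarbonyl on the aromatic nitrogen gives a 3.4-fold higher number from compound 1 to compound 4 (0.53 log units; beyond the scatter), so a group without the bromo chain also changes the number beyond the scatter. It also gives an at least 2.9-fold lower number from compound 3 to compound 4 (0.47 log units; beyond the scatter) and an at least 2.9-fold lower number from compound 2 to compound 4 (0.47 log units; beyond the scatter), which places compound 4 between compound 1 and the two amide compounds. These two steps are only lower bounds because compound 2 and compound 3 sit at a limit: the limit of > 256000 nM in this assay, at which 2 of the 4 values shown sit.

The step between compound 2 and compound 3 cannot be read. Also open, going by these compounds, is whether an amine or a carboxylic acid in place of the amide, or a longer chain, would stay at that limit.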